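The source may report more compounds than this note shows. Statements on the series, on what has been measured and on what is new or still open speak of the compounds shown alone.

Compound 1 `CCC(=O)c1ccc2c(c1)C(n1ccccc1=O)=CC(C)(C)O2` is one of three compounds sharing a core, all measured in a functional assay (aorta) with Rattus norvegicus as the target; a lower number here means a less potent compound, a higher number a more potent compound, by a factor of ten per unit of this negative logarithm. Compound 1 gives 6.63, the second highest of the three numbers: compound 3 `CC1(C)C=C(n2ccccc2=O)c2cc(C(=O)c3c(F)cccc3F)ccc2O1` gives 6.97, a number 0.34 log units higher from compound 1 to compound 3 (beyond the scatter), while compound 2 `COc1ccc(C(=O)c2ccc3c(c2)C(n2ccccc2=O)=CC(C)(C)O3)cc1` gives 6.15, a number 0.48 log units lower from compound 1 to compound 2 (beyond the scatter). Compound 4 `CC1(C)C=C(n2ccccc2=O)c2cc(C(=N)NO)ccc2O1` differs from compound 1 in one place: a group of 4 heavy atoms (1 carbon, 2 nitrogen, 1 oxygen; no ring) in place of a group of 4 heavy atoms (3 carbon, 1 oxygen; no ring), on an aromatic carbon. The measured steps each swap only the group on a carbonyl carbon, keeping the propanoyl-type carbonyl, so none bears directly on this change; they show modest shifts, the largest being a number 0.82 log units higher from compound 2 to compound 3 (beyond the scatter). The change here is of a different kind, and a modest decrease beyond the scatter is expected, a number 0.73 log units lower from compound 1 to compound 4 (beyond the scatter). Compound 4 is thus estimated at 5.9, within 5 to 6.8.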

Compound 4, logarithm of the reciprocal of the active concentration, log(1/C): 5.99
Compound 4: middle estimate off by 0.09 log units, on the low side; the measured number falls inside the stated range.
By their numbers in this assay, from the lowest: compounds 4 and 2 (each within the scatter of the next); then compound 1; then compound 3.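

In this assay, among the compounds shown here, the step of a number 0.64 log units lower from compound 1 to compound 4 (beyond the scatter) comes from replacing the whole propanoyl group on this aromatic carbon, not just the group on the carbonyl carbon, which was all the earlier steps changed. The position therefore keeps measurable activity without that carbonyl, at a modest cost, and the entering group has more hydrogen-bond donors than propanoyl. Nothing available accounts for the drop. Still open, from the compounds shown here alone, is how an amine, a nitrile or a carboxylic acid on this aromatic carbon would compare with propanoyl. Going by these compounds, a longer acyl chain is equally open.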